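The compounds below may be only part of what the source reports. "The series", "measured", "known", "first", "only" and "open" are said of these compounds alone.

Measured compounds:
Compound 1, `COc1ccc(C2=NN(C(=O)c3ccc4c(c3)OCCO4)C(c3ccccc3F)C2)cc1`: 3470 nM
Compound 2, `COc1ccc(C2=NN(C(=O)C3COc4ccccc4O3)C(c3ccc(F)cc3)C2)cc1`: 6190 nM
Compound 3, `COc1ccc(C2=NN(C(=O)C3COc4ccccc4O3)C(c3ccccc3)C2)cc1`: 6310 nM

In a functional assay on WM 266-4 cells (Homo sapiens) for inhibition, read by MTT assay, with a stated time of 24 h (a lower number here means a stronger inhibitor of growth, a higher number a weaker inhibitor of growth), compound 2 gives 6190 nM, the second highest of the three numbers; compound 3 gives 6310 nM, and the step of a 1.0-fold higher number from compound 2 to compound 3 (0.01 log units; within the scatter) is within the scatter. Compound 1 gives 3470 nM, a lower number, but also within the scatter of compound 2.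

Compound 4, `COc1ccc(C2=NN(C(=O)c3ccc4c(c3)OCCO4)C(c3ccc(F)cc3)C2)cc1`, has not yet been measured. It differs from compound 2 in one place: 2,3-dihydro-1,4-benzodioxin-6-yl in place of 2,3-dihydro-1,4-benzodioxin-2-yl on a carbonyl carbon. Among the measured compounds shown here, no measured step covers exactly this change. For the measured compounds named here, the only measured step, a 1.0-fold higher number from compound 2 to compound 3 (0.01 log units; within the scatter), concerns the fluoro and not the carbonyl substituent, so it bears on this case only indirectly. Compound 1, which carries the same 2,3-dihydro-1,4-benzodioxin-6-yl group as compound 4, sits within the scatter of compound 2, which suggests that the change from the 2-yl to the 6-yl group does little here.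

Compound 4 is therefore expected to land close to compound 2, with the step of a 1.4-fold lower number from compound 2 to compound 4 (0.14 log units; within the scatter) expected to stay within the scatter. The estimate for compound 4 is 4500 nM, with a range from 1800 nM to 11000 nM.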

Compound 4, concentration for 50% growth inhibition: 3780 nM
The estimate for compound 4 lay 1.2-fold (0.08 log units) above the measured number; the measured number falls inside the stated range.
By their numbers in this assay, from the lowest: compounds 1, 4, 2 and 3 (each within the scatter of the next).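

In this assay, among the compounds shown here, the exchange of 2,3-dihydro-1,4-benzodioxin-2-yl for 2,3-dihydro-1,4-benzodioxin-6-yl on the carbonyl carbon gives a 1.6-fold lower number from compound 2 to compound 4 (0.21 log units; within the scatter) and so stays within the scatter, a direct reading of this change that the earlier compounds did not give. With the 2,3-dihydro-1,4-benzodioxin-6-yl group held fixed, 4-fluorophenyl in place of 2-fluorophenyl on the saturated ring carbon gives a 1.1-fold higher number from compound 1 to compound 4 (0.04 log units; within the scatter) and also stays within the scatter, so these two fluorophenyl groups cannot be told apart here. Nothing available explains why these numbers lie so close together.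

The compounds shown leave open whether a different group on the carbonyl carbon, such as a simple amine or a longer alkyl chain, would give a step beyond the scatter. They also leave open whether a carboxylic acid on the phenyl ring of the shared core would do so.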